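Swapping the Nitrile for a Hydroxymethyl Group

The source may hold more compounds than are shown below. What is called first, only, known or untested is meant among the compounds shown, and "the series" means these compounds.

Among the three compounds measured so far, compound 3 `CCN(Cc1cccs1)C(=O)COc1ccc(C#N)cc1` stands at the top end of the numbers: in an assay on HEK293 cells for agonist activity at transient receptor potential cation channel subfamily M member 8 (Homo sapiens), read by fluorescence and calcium flux, with a stated time of 15 min (on this read-out higher numbers stand for an effect only at larger amounts of compound and lower numbers for an effect already at smaller amounts), compound 3 gives 1990 nM. Compound 1 `CCN(Cc1cccs1)C(=O)COc1ccc(C(F)(F)F)cc1` gives 236 nM, and compound 2 `CCc1ccc(OCC(=O)N(CC)Cc2cccs2)cc1` gives 67 nM. The step of an 8.4-fold higher number from compound 1 to compound 3 (0.93 log units; beyond the scatter) and the step of a 30-fold higher number from compound 2 to compound 3 (1.47 log units; beyond the scatter) both lead up to compound 3, while the step of a 3.5-fold lower number from compound 1 to compound 2 (0.55 log units; beyond the scatter) runs the other way.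

Compound 4 `CCN(Cc1cccs1)C(=O)COc1ccc(CO)cc1` differs from compound 3 in one place: hydroxymethyl in place of cyano on an aromatic carbon. Among the compounds with values here, the incoming hydroxymethyl carries a hydrogen-bond donor, which none of the measured compounds has at this place, so no measured step tests the change directly. On these data alone, the steps into compound 3 show that replacing ethyl or trifluoromethyl with cyano gave higher numbers, but how a hydroxymethyl compares with cyano is unknown. The expectation is therefore a step of a 1.5-fold higher number from compound 3 to compound 4 (0.18 log units; within the scatter), likely within the scatter. The estimate for compound 4 is 3000 nM, expected to fall between 1000 nM and 10000 nM.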

Compound 4, half-maximal effective concentration: 21900 nM
Beside the measured number, compound 4's estimate is 7.3-fold (0.86 log units) below it, outside the stated range (above it).
By their numbers in this assay, from the lowest: compound 2; then compound 1; then compound 3; then compound 4.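

In this assay, the two groups at this aromatic carbon have the same count of heavy atoms, yet hydroxymethyl in place of cyano gives an 11-fold higher number from compound 3 to compound 4 (1.04 log units; beyond the scatter), so size alone, counted this way, does not set the number here. Within the data shown here, the other two routes into compound 4 are larger still: a 93-fold higher number from compound 1 to compound 4 (1.97 log units; beyond the scatter), and a 330-fold higher number from compound 2 to compound 4 (2.51 log units; beyond the scatter), the latter for hydroxy in place of methyl on the chain carbon bound to the ring, so across these four compounds, the only group with a hydrogen-bond donor gives the highest number. No measurement shown here explains this drop.

On these data alone, whether the donor hydrogen itself matters stays open, and a methoxymethyl group would separate it from the oxygen atom alone. How an aminomethyl group or a carboxylic acid would behave at this place is also unknown.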